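The source may report more compounds than this note shows. Statements on the series, on what has been measured and on what is new or still open speak of the compounds shown alone.

Measured so far in a functional assay on MGC-803 cells (Homo sapiens) for antiproliferative activity, read by MTT assay, with a stated time of 48 h (on this read-out lower numbers stand for stronger inhibition and higher numbers for weaker inhibition), are these compounds:
- Compound 1 `COc1ccc(CN(C(=O)CSc2nc3ccccc3s2)c2cc(OC)c(OC)c(OC)c2)cc1C` – 6360 nM
- Compound 2 `COc1ccc(CN(C(=O)CSc2nc3ccccc3s2)c2cc(OC)c(OC)c(OC)c2)cc1` – 163 nM
- Compound 3 `COc1ccc(CN(C(=O)CSc2nc3ccccc3s2)c2cc(OC)c(OC)c(OC)c2)cc1O` – 35 nM

Compound 3 has the lowest number of the three, which makes it the most potent so far. The gaps leading to it, a 4.7-fold lower number from compound 2 to compound 3 (0.67 log units; beyond the scatter) and a 180-fold lower number from compound 1 to compound 3 (2.26 log units; beyond the scatter), both lie beyond the scatter.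

Compound 4 `COc1ccc(CN(C(=O)CSc2nc3cc(Cl)ccc3s2)c2cc(OC)c(OC)c(OC)c2)cc1O` keeps everything in compound 3 except for one swap, chloro in place of hydrogen on an aromatic carbon, which turns 1,3-benzothiazol-2-yl into 5-chloro-1,3-benzothiazol-2-yl.

Going by the values given here, no measured step touches that site, since all three changes lie elsewhere in the molecule. They therefore offer only indirect guidance. Among these compounds, one small swap produced a large change in a 39-fold lower number from compound 1 to compound 2 (1.59 log units; beyond the scatter) and a modest one in a 4.7-fold lower number from compound 2 to compound 3 (0.67 log units; beyond the scatter). This shows that the series can respond strongly, but not which way a chloro at the new site will push the number.

With no direct evidence, no clear shift is expected in this assay, and the range must stay wide. The expected change is a 1.4-fold higher number from compound 3 to compound 4 (0.15 log units; within the scatter) and this estimated step stays within the scatter. For compound 4 the estimated value is 50 nM with an expected range from 12 nM to 250 nM for four of five measurements.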

Compound 4, half-maximal inhibitory concentration: 85 nM
Compound 4: middle estimate off by 1.7-fold (0.23 log units), on the low side; low and high end bracket the measured number.
By their numbers in this assay, from the lowest: compound 3; then compounds 4 and 2 (each within the scatter of the next); then compound 1.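

Turning 1,3-benzothiazol-2-yl into 5-chloro-1,3-benzothiazol-2-yl gives a 2.4-fold higher number from compound 3 to compound 4 (0.39 log units; beyond the scatter) in this assay, and this is the only measured change on this part of the molecule. It shows that this position is not silent: adding a single chlorine atom to the six-membered aromatic ring of the fused system weakens inhibition, though only modestly, and compound 4 still gives a value of 85 nM. No measurement available here explains why the number rises at this site.

From the compounds shown here alone, with only hydrogen and chloro to compare at this position, it remains open whether the rise is specific to chloro or would also appear with another group there, such as fluoro, methoxy or an amine, any of which could move the number in either direction. Going by these compounds, it is also open whether the gain in inhibition seen with the hydroxy group in a 4.7-fold lower number from compound 2 to compound 3 (0.67 log units; beyond the scatter) would hold to the same extent with the chloro present, since that would require a chloro compound with hydrogen in place of that hydroxy group.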